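The source may report more compounds than this note shows. Statements on the series, on what has been measured and on what is new or still open speak of the compounds shown alone.

Compound 1 `CN1CCN(c2ccc(S(=O)(=O)Oc3cccc(F)c3)cc2)C1=O` stands only at a limit in a functional assay on HT-29 cells (Homo sapiens) for antiproliferative activity, read by sulforhodamine B assay, with a stated time of 48 h; on this read-out higher numbers stand for weaker inhibition and lower numbers for stronger inhibition: compound 1 gives > 100000 nM, a limit rather than a number. Compound 2 `COc1ccc(OS(=O)(=O)c2ccc(N3CCN(C)C3=O)cc2)cc1` likewise gives > 100000 nM, again a limit. The step that the two limits leave unreadable from compound 1 to compound 2 is therefore unreadable, and both values sit at the limit of > 100000 nM in this assay, at which 2 of the 2 values shown sit. Compound 3 `CCCCN1CCN(c2ccc(S(=O)(=O)Oc3cccc(F)c3)cc2)C1=O` differs from compound 1 by propyl in place of hydrogen on a saturated chain carbon bound to an amide-type nitrogen in a ring. Among the compounds with values here, no measured step touches this kind of change, so nothing fixes its direction or size. Compound 3 is expected to remain at the limit, an estimated step of a number no higher from compound 1 to compound 3 (the limit leaves the size open). The estimate for compound 3 is 100000 nM, within 30000 nM to 300000 nM.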

Compound 3, half-maximal inhibitory concentration: 76000 nM
Compound 3: middle estimate off by 1.3-fold (0.12 log units), on the high side; low and high end bracket the measured number.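

The change of hydrogen to propyl on a saturated chain carbon bound to an amide-type nitrogen in a ring is the only change shown that gives a number in this assay (an at least 1.3-fold lower number from compound 1 to compound 3 (0.11 log units; that floor lies within the scatter)). From the compounds shown here alone, that floor lies within the usual scatter, so the true size of the step stays open. Compound 1 and compound 2 remain at a limit, and the step between them cannot be read: the limit of > 100000 nM in this assay, at which 2 of the 3 values shown sit.

Going by these compounds, whether a longer chain, or an amine or a carboxylic acid at the end of the chain, would shift the number remains open. Also open, on these data alone, is whether propyl in the same place acts alike on the 4-methoxyphenyl compound 2.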